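From compound 2 to compound 3: adding a chloro

A few compounds are considered here, and "the series" means these few. Any claim that something is new, unique, unknown or untested is made for them only; others in the source may bear on it.

Measured in an ADME assay on HCT-116 cells (Homo sapiens) for cytotoxicity, read by CellTiter-Glo, with a stated time of 72 h; a lower number here means a stronger inhibitor, a higher number a weaker inhibitor:
- Compound 1 `Cc1c(C)c(S(=O)(=O)N2CCC(N3CCC(C)CC3)CC2)c(C)c2c1OC(C)(C)C2`: > 10000 nM
- Compound 2 `CC1CCN(C2CCN(S(=O)(=O)c3cccnc3)CC2)CC1`: > 10000 nM

Compound 2 gives > 10000 nM, which is a limit of the assay and not a number. All that has been measured so far is the limit of > 10000 nM in this assay, at which 2 of the 2 values shown sit. Compound 3 `CC1CCN(C2CCN(S(=O)(=O)c3ccc(Cl)nc3)CC2)CC1` carries one change, (chloro in place of hydrogen on an aromatic carbon), which turns pyridin-3-yl into 6-chloropyridin-3-yl. No measured pair sizes this change, so no step beyond the scatter is expected in this assay, and no direction is assigned. The estimate for compound 3 is an expected value of 12000 nM, with an expected range of 5000 nM to 30000 nM.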

Compound 3, half-maximal inhibitory concentration: > 10000 nM
Compound 3: no number, only a limit (the forecaster's own chance of this, stated with the estimate: 80%); the middle value does not contradict the limit.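

In this assay compound 3 gives > 10000 nM, which is a limit and not a number. With compound 2 also at a limit, no step can be read between compound 2 and compound 3. The compounds shown leave open what effect the chloro has, and whether any related compound would give a readable number.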